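Ethyl for 2,4-dimethylphenyl: compound 3 to compound 4

The compounds below may be only part of what the source reports. "The series", "measured", "known", "first", "only" and "open" are said of these compounds alone.

In a functional assay on MCF7 cells (Homo sapiens) for antiproliferative activity, read by MTT assay, with a stated time of 48 h (on this read-out higher numbers stand for weaker inhibition and lower numbers for stronger inhibition), compound 1 (`COc1cccc(N2CCN(C(=O)/C=C/c3ccc(O)c(O)c3)CC2)c1`) gives 0.92 ug/mL while compound 2 (`O=C(/C=C/c1ccc(O)c(O)c1)N1CCN(c2ccc([N+](=O)[O-])cc2)CC1`) gives 1.14 ug/mL and compound 3 (`Cc1ccc(N2CCN(C(=O)/C=C/c3ccc(O)c(O)c3)CC2)c(C)c1`) gives 0.78 ug/mL on the same read-out. Compound 3 therefore stands within the scatter of both other compounds, as shown by a 1.2-fold lower number from compound 1 to compound 3 (0.07 log units; within the scatter) and by a 1.5-fold lower number from compound 2 to compound 3 (0.16 log units; within the scatter) in this series.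

Compound 4 (`CCN1CCN(C(=O)/C=C/c2ccc(O)c(O)c2)CC1`) carries ethyl in place of 2,4-dimethylphenyl on an amine nitrogen in a ring. The measured steps closest to this change are a 1.2-fold higher number from compound 1 to compound 2 (0.09 log units; within the scatter) together with the two steps into compound 3 already given. All three stay within the scatter, but each swaps one substituted phenyl group for another. None of them removes the aromatic ring from that nitrogen, so the measured compounds do not show what an ethyl group will do here, and the range must stay wide.

A modest step toward a higher number is expected in this assay and it is not expected to lie clearly beyond the scatter. The estimated step is a 1.9-fold higher number from compound 3 to compound 4 (0.28 log units; within the scatter) on this reckoning. Compound 4 is expected at 1.5 ug/mL (estimated range 0.6 ug/mL to 4.5 ug/mL) in this assay for now.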

Compound 4, half-maximal inhibitory concentration: 2.06 ug/mL
Compound 4: middle estimate off by 1.4-fold (0.14 log units), on the low side; the range from low to high includes it.
By their numbers in this assay, from the lowest: compounds 3, 1, 2 and 4 (each within the scatter of the next, the first and the last beyond it).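

In this assay, among these compounds, compound 4 is the first compound without an aromatic ring on the amine nitrogen, and this change gives a 2.6-fold higher number from compound 3 to compound 4 (0.42 log units; beyond the scatter) and a 2.2-fold higher number from compound 1 to compound 4 (0.35 log units; beyond the scatter), while a 1.8-fold higher number from compound 2 to compound 4 (0.26 log units; within the scatter) stays within the scatter. The substituted phenyl groups could not be separated from one another, but ethyl can be separated from two of them, so the outcome of this change depends on which phenyl group leaves, with the 4-nitrophenyl of compound 2 going against any general penalty for ethyl; even so, the steps are modest, and compound 4 still gives 2.06 ug/mL with far fewer heavy atoms on that nitrogen. No available evidence bears on the reason for these steps.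

These compounds do not separate the loss of the aromatic ring from the loss of carbon atoms at this position, and a cyclohexyl group on the same nitrogen would address that directly. On these data alone, it also remains open how the read-out responds to a longer chain such as butyl, to a benzyl group, or to a carboxylic acid carried on a short chain at this nitrogen.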